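One larger group on a carbonyl carbon

This account rests on a few compounds, and the source may have more. Where it says the series, first, only, none or still open, it means among the compounds named here.

compound 1 `CCn1c(C(=O)NCC#N)ccc1C(CC)(CC)c1ccc(OCCC(O)(CC)CC)c(C)c1` gives 17800 nM
compound 2 `C#CC(C)OC(=O)c1ccc(C(CC)(CC)c2ccc(OCCC(O)(CC)CC)c(C)c2)n1CC` gives 14800 nM

Both numbers come from a functional assay on PC-3 cells (Homo sapiens) for antiproliferative activity, read by MTT assay, with a stated time of 48 h (a higher number here means a weaker inhibitor, a lower number a stronger inhibitor), and a single change links the two compounds. Compound 2 stands level with compound 1 on these numbers, the gap between them being within the scatter. Compound 3 `CCOC(=O)C(CC(=O)OC)NC(=O)c1ccc(C(CC)(CC)c2ccc(OCCC(O)(CC)CC)c(C)c2)n1CC` differs from compound 2 in one place, on a carbonyl carbon, and the change is a group of 12 heavy atoms (7 carbon, 1 nitrogen, 4 oxygen; no ring) in place of a group of 5 heavy atoms (4 carbon, 1 oxygen; no ring), on a carbonyl carbon while the shared core stays the same. Going by the values given here, only one measured step bears on this, the swap of (cyanomethyl)amino for (1-methylprop-2-yn-1-yl)oxy on a carbonyl carbon, and it lies within the scatter. With only a 1.2-fold lower number from compound 1 to compound 2 (0.08 log units; within the scatter) to go on, no step beyond the scatter is expected in this assay for this larger group, and the uncertainty stays wide. The expected change is a 1.0-fold higher number from compound 2 to compound 3 (0.01 log units; within the scatter) and nothing larger is foreseen. Compound 3 is estimated at 15000 nM with 6000 nM to 35000 nM as its expected range.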

Compound 3, half-maximal inhibitory concentration: 5840 nM
For compound 3 the middle estimate is 2.6-fold (0.41 log units) above the measured one; measured number below the stated range.
By their numbers in this assay, from the lowest: compound 3; then compounds 2 and 1 (each within the scatter of the next).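

This position on the carbonyl carbon can respond to change: in this assay the larger group gives a 2.5-fold lower number from compound 2 to compound 3 (0.40 log units; beyond the scatter) and so moves beyond the scatter, which the earlier swap did not do with its a 1.2-fold lower number from compound 1 to compound 2 (0.08 log units; within the scatter) alone. Compound 3 also keeps its amide link to the carbonyl carbon, as compound 1 does, and the change on that amide-type nitrogen gives a 3.0-fold lower number from compound 1 to compound 3 (0.48 log units; beyond the scatter) as a modest step. No measurement offered here accounts for this gain.

The entering group differs in heavy atoms, hydrogen-bond donors and hydrogen-bond acceptors all at once, so these compounds cannot show which of these differences matters. On these data alone, how the activity would respond to a carboxylic acid or a longer chain at this carbonyl carbon remains open.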